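The compounds below may be only part of what the source reports. "The series", "measured", "known", "first", "only" and "open" are said of these compounds alone.

Measured so far in a functional assay on MCF7 cells (Homo sapiens) for inhibition, read by sulforhodamine B assay; on this read-out higher numbers stand for weaker inhibition and lower numbers for stronger inhibition:
Compound 1 `CCCc1ccc(NC2=CC(=O)c3nc4n(c3C2=O)[C@H]2OC[C@@H](O)[C@H]2OC4)cc1`: 4660 nM
Compound 2 `O=C1C=C(N2CCCCC2)C(=O)c2c1nc1n2[C@H]2OC[C@@H](O)[C@H]2OC1`: > 8000 nM
Compound 3 `CCCN(CCC)C1=CC(=O)c2nc3n(c2C1=O)[C@H]1OC[C@@H](O)[C@H]1OC3`: > 16000 nM

Among the measured compounds shown here, compound 1 gives the only readable number in this assay, 4660 nM. Compound 2 returns only a limit, > 8000 nM. Compound 3 likewise returns only a limit, > 16000 nM, so compound 3 cannot be placed against the others by a number. For the measured compounds named here, the single measured step, a step that the two limits leave unreadable from compound 2 to compound 3, runs between two limits, the limit of > 8000 nM in this assay, at which 1 of the 3 values shown sits, and (the limit of > 16000 nM in this assay, at which 1 of the 3 values shown sits), and its size is not readable.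

Compound 4 `O=C1C=C(Nc2ccccc2F)C(=O)c2c1nc1n2[C@H]2OC[C@@H](O)[C@H]2OC1` is not yet measured. Change: (2-fluorophenyl)amino in place of dipropylamino on a double-bonded ring carbon. Going by the values given here, no measured step bears on this change. The closest measured relative of compound 4 in structure is compound 1, which gives 4660 nM, and this offers a reference point. The limit of compound 3 leaves the size of any step open; the direction expected is toward a readable value. Compound 4 is estimated at 5000 nM, range 1500 nM to 16000 nM. The step this estimate implies is an at least 3.2-fold lower number from compound 3 to compound 4 (0.50 log units; beyond the scatter).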

Compound 4, half-maximal inhibitory concentration: 3640 nM
For compound 4 the middle estimate is 1.4-fold (0.14 log units) above the measured one; the measured number falls inside the stated range.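

In this assay, from the compounds shown here alone, (2-fluorophenyl)amino on the double-bonded ring carbon gives a readable number where dipropylamino and piperidin-1-yl give only limits of the assay: the steps are an at least 4.3-fold lower number from compound 3 to compound 4 (0.64 log units; beyond the scatter) and an at least 2.1-fold lower number from compound 2 to compound 4 (0.34 log units; beyond the scatter) and both sizes stay open on one side, while the step from compound 2 to compound 3 cannot be read. Placing 2-fluorophenyl for 4-propylphenyl on an amine nitrogen gives a 1.3-fold lower number from compound 1 to compound 4 (0.11 log units; within the scatter) and does not separate the two groups in this assay. Among the four compounds, the two with a phenyl ring on an amine nitrogen that keeps its hydrogen give numbers and the other two give limits, and none goes against this.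

A benzylamino or N-methyl-N-phenylamino group at this carbon would separate the aromatic ring from the amine hydrogen, which enter together here. Nothing shown gives a cause for these steps.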